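Adding 4-chlorophenyl to the amide-type nitrogen of compound 3

The source may report more compounds than this note shows. Statements on the series, on what has been measured and on what is new or still open speak of the compounds shown alone.

In a functional assay on HCT-116 cells (Homo sapiens) for antiproliferative activity, read by MTT assay, with a stated time of 72 h (on this read-out lower numbers stand for stronger inhibition and higher numbers for weaker inhibition), compound 3 `O=C1COc2ccc(-c3cnc(Cl)c(NS(=O)(=O)c4ccc(F)cc4)c3)cc2N1` gives > 40000 nM, which is a limit and not a number. Compound 1 `O=C1COc2ccc(-c3cnc(Cl)c(NS(=O)(=O)c4ccc(F)cc4)c3)cc2N1C1CCCCC1`, with cyclohexyl at the same place, gives > 40000 nM, also a limit. Compound 2 `COc1ccc(N2C(=O)COc3ccc(-c4cnc(Cl)c(NS(=O)(=O)c5ccc(F)cc5)c4)cc32)cc1`, with 4-methoxyphenyl there, gives 30100 nM. Compound 4 `O=C1COc2ccc(-c3cnc(Cl)c(NS(=O)(=O)c4ccc(F)cc4)c3)cc2N1c1ccc(Cl)cc1` carries 4-chlorophenyl in place of the hydrogen of compound 3 on the amide-type nitrogen in a ring (4-chlorophenyl in place of hydrogen on an amide-type nitrogen in a ring). The closest guide is the aryl-to-hydrogen step an at least 1.3-fold higher number from compound 2 to compound 3 (0.12 log units; that floor lies within the scatter), and the step of an at least 1.3-fold lower number from compound 1 to compound 2 (0.12 log units; that floor lies within the scatter) is of like size; both floors lie within the scatter. The expected change is therefore small, an at least 1.3-fold lower number from compound 3 to compound 4 (0.12 log units; that floor lies within the scatter), towards a lower number at most. For compound 4 the estimated value is 30000 nM, with an expected range of 12000 nM to 60000 nM.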

Compound 4, half-maximal inhibitory concentration: 27900 nM
Beside the measured number, compound 4's estimate is 1.1-fold (0.03 log units) above it; measured number inside the range.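

In this assay, 4-chlorophenyl on the amide-type nitrogen gives a measured number where hydrogen and cyclohexyl do not, yet both steps stay within the scatter (an at least 1.4-fold lower number from compound 3 to compound 4 (0.15 log units; that floor lies within the scatter)) (an at least 1.4-fold lower number from compound 1 to compound 4 (0.15 log units; that floor lies within the scatter)). Chloro in place of methoxy on the aryl ring also leaves the read-out within the scatter (a 1.1-fold lower number from compound 2 to compound 4 (0.03 log units; within the scatter)), so compound 2 and compound 4 are not told apart. The first two steps are floors only, set by a limit of the assay: the limit of > 40000 nM in this assay, at which 2 of the 4 values shown sit. As far as these compounds go, whether an amine or a carboxylic acid on that aryl ring, or a longer chain on the nitrogen, would move the value beyond the scatter remains open.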